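Swapping Oxygen for Sulfur in a Dichlorophenyl Linker

The source may report more compounds than this note shows. Statements on the series, on what has been measured and on what is new or still open speak of the compounds shown alone.

Of the compounds shown here, three built on one shared core have been measured so far. Compound 1 `Nc1cc(N)c2nc(-c3ccccc3)c(Oc3ccc(Cl)c(Cl)c3)nc2c1` carries a 3,4-dichlorophenoxy group; in a functional assay on M14 cells (Homo sapiens) for inhibition, read by sulforhodamine B assay, with a stated time of 48 h (a lower number here means a stronger inhibitor of growth, a higher number a weaker inhibitor of growth), compound 1 gives 14100 nM. Compound 2 `Nc1cc(N)c2nc(-c3ccccc3)c(NCc3ccc(Cl)c(Cl)c3)nc2c1` gives 15800 nM in this assay, and compound 3 `COc1cc(CNc2nc3cc(N)cc(N)c3nc2-c2ccccc2)cc(OC)c1OC` gives 9550 nM. Compound 1 holds the second highest of the three numbers; its nearest neighbour is compound 2 and its furthest is compound 3, and both gaps lie within the usual scatter of repeated measurements, so no order can be read among the three.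

Compound 4 `Nc1cc(N)c2nc(-c3ccccc3)c(Sc3ccc(Cl)c(Cl)c3)nc2c1` has not yet been measured. It differs from compound 1 in one place: (3,4-dichlorophenyl)sulfanyl in place of 3,4-dichlorophenoxy on an aromatic carbon. For the measured compounds named here, no pair of measured compounds differs in a single place, so no measured step speaks to this change directly. The group that leaves and the group that enters match in everything counted above, so a step in this assay of no more than the scatter is expected, in no clear direction. Compound 4 is therefore estimated at 14000 nM, with a range from 6000 nM to 33000 nM, which means an expected step of a 1.0-fold lower number from compound 1 to compound 4 (0.00 log units; within the scatter).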

Compound 4, concentration for 50% growth inhibition: 32400 nM
The estimate for compound 4 lay 2.3-fold (0.36 log units) below the measured number; the range from low to high includes it.
By their numbers in this assay, from the lowest: compounds 3, 1 and 2 (each within the scatter of the next); then compound 4.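

For the compounds shown here, until now no measured pair differed in a single place, so this is the first direct reading of a change at this position, on an aromatic carbon next to the ring nitrogen and ortho to a phenyl group. In this assay, (3,4-dichlorophenyl)sulfanyl in place of 3,4-dichlorophenoxy brings a 2.3-fold higher number from compound 1 to compound 4 (0.36 log units; beyond the scatter) and so a modest loss of growth inhibition, even though the two groups match in heavy-atom count, ring, hydrogen-bond donors, acceptors and charge. Nothing available here explains why the sulfur link gives the weaker inhibitor.

The compounds shown leave open how a plain amine link to the same 3,4-dichlorophenyl ring, or a sulfone in place of the sulfur, would read at this position. They also leave open whether this step would hold with other aromatic rings on the link.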